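A few compounds are considered here, and "the series" means these few. Any claim that something is new, unique, unknown or untested is made for them only; others in the source may bear on it.

The measured compounds:
Compound 1, `CN(c1ccccc1)S(=O)(=O)c1ccc(NC(=O)C(C)(O)C(F)(F)F)cc1`, gives 2000 nM in a functional assay (Cavia porcellus) with sulfonylurea receptors; K-ATP channels (Homo sapiens) as the target; on this read-out higher numbers stand for weaker inhibition and lower numbers for stronger inhibition.
Compound 2, `CC(O)(C(=O)Nc1ccc(S(=O)(=O)c2cncnc2)cc1)C(F)(F)F`, gives only a limit in this assay, > 30000 nM.

Compound 2 thus sits at the limit of this assay, (the limit of > 30000 nM in this assay, at which 1 of the 2 values shown sits), and no number is known for it. Compound 3, `CC(O)(C(=O)Nc1ccc(S(=O)(=O)c2nccs2)cc1)C(F)(F)F`, differs from compound 2 by 1,3-thiazol-2-yl in place of pyrimidin-5-yl on a sulfonyl sulfur. Among the measured compounds shown here, the only measured step is an at least 15-fold higher number from compound 1 to compound 2 (1.17 log units; beyond the scatter); it concerns another exchange on the sulfonyl sulfur and gives no direct guide to swapping one heteroaryl for another. Compound 3 is therefore expected to stay near the limit, with no step beyond the scatter, a number no higher from compound 2 to compound 3 (the limit leaves the size open). The estimate for compound 3 is 30000 nM, between 8000 nM and 100000 nM.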

Compound 3, half-maximal inhibitory concentration: 1400 nM
Compound 3: the middle estimate sits 21-fold (1.33 log units) above what was measured; measured number below the stated range.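

At this sulfonyl sulfur, one aromatic ring cannot stand in for another: 1,3-thiazol-2-yl in place of pyrimidin-5-yl gives an at least 21-fold lower number from compound 2 to compound 3 (1.33 log units; beyond the scatter). From the compounds shown here alone, compound 2 is known only as a limit, so the full size of this step stays open: the limit of > 30000 nM in this assay, at which 1 of the 3 values shown sits. An aromatic ring on the sulfur can also match the amine-linked group, since 1,3-thiazol-2-yl in place of methyl(phenyl)amino gives a 1.4-fold lower number from compound 1 to compound 3 (0.15 log units; within the scatter). Going by these compounds, whether a plain phenyl ring, a pyridin-2-yl ring or a piperidin-1-yl group on the same sulfur would hold this level remains open.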